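Stripping the pyridazine ring back to the bare parent

The compounds below may be only part of what the source reports. "The series", "measured", "known", "first", "only" and "open" are said of these compounds alone.

Measured so far:
compound 1 `Cc1ccc(N2CCN(C(=O)Nc3nc4ccc(F)cc4s3)CC2)nn1` gives > 10000 nM in this assay
compound 2 `Cc1cc(N2CCN(C(=O)Nc3nc4ccc(F)cc4s3)CC2)nnc1Cl` gives > 10000 nM in this assay

Both compounds share one core and differ only in the aromatic ring attached to an amine nitrogen in a ring: compound 1 carries 6-methylpyridazin-3-yl, compound 2 carries 6-chloro-5-methylpyridazin-3-yl. In an assay on HEK293 cells for inhibition of transient receptor potential cation channel subfamily V member 1 (Homo sapiens), read by FLIPR, at pH 5.5 (a higher number here means a weaker inhibitor, a lower number a stronger inhibitor), compound 1 gives > 10000 nM, which is a limit of the assay rather than a number. In this assay compound 2 gives > 10000 nM, again a limit. The step that the two limits leave unreadable from compound 1 to compound 2 therefore cannot be read in either direction. Both values sit at the limit of > 10000 nM in this assay, at which 2 of the 2 values shown sit.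

Compound 3 `O=C(Nc1nc2ccc(F)cc2s1)N1CCN(c2cccnn2)CC1` continues along the same ring: pyridazin-3-yl in place of 6-chloro-5-methylpyridazin-3-yl on an amine nitrogen in a ring. For the measured compounds named here, the only measured step touches this same position, but because both of its ends are limits the limit of > 10000 nM in this assay, at which 2 of the 2 values shown sit, it gives no size to work from. With nothing measured to pull the value down, compound 3 is expected to remain at or near the limit, estimated at 15000 nM with a range from 3000 nM to 60000 nM. The step expected is a step that the limit leaves unreadable from compound 2 to compound 3, nothing beyond the scatter.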

Compound 3, half-maximal inhibitory concentration: > 10000 nM
Compound 3 was reported as a limit; the forecaster's own chance of this, stated with the estimate: 70%; the middle value is on the limit's open side.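

In this assay compound 3 gives > 10000 nM which is a limit of the assay and not a number. The steps linking compound 1, compound 2 and compound 3 therefore cannot be read, because all three compounds end on a limit: the limit of > 10000 nM in this assay, at which 3 of the 3 values shown sit.

The compounds shown leave open whether any group at this position gives a readable value in this assay and, if so, how large the change would be.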